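Working notes: ether chain size and agonist potency

This account rests on a few compounds, and the source may have more. Where it says the series, first, only, none or still open, it means among the compounds named here.

Compound 1 `CCOc1ccccc1OC(C)C1=NCCN1` gives 10000 nM in a functional assay on CHO cells for agonist activity at Alpha-2C adrenergic receptor (Homo sapiens); on this read-out higher numbers stand for an effect only at larger amounts of compound and lower numbers for an effect already at smaller amounts. Compound 2 `CC(C)Oc1ccccc1OC(C)C1=NCCN1` gives 100 nM in this assay.

Among the measured compounds shown here, compound 2 has the lower of the two numbers; the only neighbour is compound 1, and the step of a 100-fold lower number from compound 1 to compound 2 (2.00 log units; beyond the scatter) separates them. Compound 3 `COc1ccccc1OC(C)C1=NCCN1` differs from compound 2 by methyl in place of isopropyl on an oxygen on an aromatic ring. For the measured compounds named here, the sole measured step bearing on this place, a 100-fold lower number from compound 1 to compound 2 (2.00 log units; beyond the scatter), was large, and it went toward the larger chain. Compound 3 moves the other way and past the size of compound 1, so a large rise in number is expected. Compound 3 is therefore expected to show a 200-fold higher number from compound 2 to compound 3 (2.30 log units; beyond the scatter). Compound 3 is estimated at 20000 nM, between 3000 nM and 100000 nM.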

Compound 3, half-maximal effective concentration: 9770 nM
Beside the measured number, compound 3's estimate is 2.0-fold (0.31 log units) above it; measured number inside the range.
By their numbers in this assay, from the lowest: compound 2; then compounds 3 and 1 (each within the scatter of the next).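

In this assay, isopropoxy to methoxy gives a 98-fold higher number from compound 2 to compound 3 (1.99 log units; beyond the scatter), while hydrogen in place of methyl on the chain carbon gives a 1.0-fold lower number from compound 1 to compound 3 (0.01 log units; within the scatter), so the number does not follow chain size in even steps. Among the three ethers, only the isopropyl group of compound 2 stands apart, and the large effect at this oxygen is tied to that group rather than spread across the series. No available evidence bears on the reason for this uneven response.

Still open, on these data alone, is how a longer straight chain such as propyl or a bulkier group such as tert-butyl or cyclopropyl would read at this oxygen.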